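This account rests on a few compounds, and the source may have more. Where it says the series, first, only, none or still open, it means among the compounds named here.

Measured compounds:
compound 1 `Nc1cc(N)c2nc(-c3ccccc3)c(Oc3ccc(Cl)c(Cl)c3)nc2c1` — 63100 nM
compound 2 `CCOC(=O)[C@H](CCC(=O)O)NC(=O)c1ccc(Sc2nc3cc(N)cc(N)c3nc2-c2ccccc2)cc1` — < 100000 nM
compound 3 `COc1cc(CNc2nc3cc(N)cc(N)c3nc2-c2ccccc2)cc(OC)c1OC` — 17800 nM

In a functional assay on TK-10 cells (Homo sapiens) for inhibition, read by sulforhodamine B assay, with a stated time of 48 h (a higher number here means a weaker inhibitor of growth, a lower number a stronger inhibitor of growth), compound 1 gives 63100 nM, the higher of the two numbers recorded. Compound 3 gives 17800 nM, a lower number, and the gap to compound 1 lies beyond the scatter. For compound 2 the assay records only a limit, < 100000 nM, not a number (the limit of < 100000 nM in this assay, at which 1 of the 3 values shown sits). Compound 4 `COc1ccc(Sc2nc3cc(N)cc(N)c3nc2-c2ccccc2)cc1` is not yet measured; it differs from compound 1 by (4-methoxyphenyl)sulfanyl in place of 3,4-dichlorophenoxy on an aromatic carbon. Among the measured compounds shown here, no measured pair shows this change. In this assay the expected step is a 1.6-fold lower number from compound 1 to compound 4 (0.20 log units; within the scatter), a modest change leaning toward a lower number. Compound 4 is therefore estimated at 40000 nM, within 12000 nM to 100000 nM.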

Compound 4, concentration for total growth inhibition: 30200 nM
The estimate for compound 4 lay 1.3-fold (0.12 log units) above the measured number; the range from low to high includes it.
By their numbers in this assay, from the lowest: compounds 3 and 4 (each within the scatter of the next); then compound 1.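

In this assay, placing (4-methoxyphenyl)sulfanyl in place of 3,4-dichlorophenoxy on this aromatic carbon gives a 2.1-fold lower number from compound 1 to compound 4 (0.32 log units; beyond the scatter). Among the compounds shown here, this is the first one-place comparison at this position, and it shows that the number responds to this change, though only modestly. No measurement shown bears on what lies behind the step.

The change alters the linking atom and the ring substituents together, and the compounds shown leave open which of them carries the step. A 3,4-dichlorophenylsulfanyl or 4-methoxyphenoxy group at this position would separate the two.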